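Trimming the urea aryl in a pyrazole growth-inhibitor series

The source may report more compounds than this note shows. Statements on the series, on what has been measured and on what is new or still open speak of the compounds shown alone.

Among the compounds with values here, compound 1 `COc1cc(-c2nn(-c3cccc(NC(=O)Nc4cc(C(F)(F)F)cc(C(F)(F)F)c4)c3)cc2-c2ccncc2)ccc1Cl` is the only compound here with a number in a functional assay on UO-31 cells (Homo sapiens) for inhibition, read by sulforhodamine B assay, with a stated time of 48 h; a higher number here means a weaker inhibitor of growth, a lower number a stronger inhibitor of growth; in this assay compound 1 gives 1280 nM. Compound 2 `O=C(Nc1cccc(-n2cc(-c3ccncc3)c(-c3ccc(Cl)c(O)c3)n2)c1)Nc1ccc(Cl)c(Cl)c1` stands at a limit of this assay, > 32500 nM, which is a limit and not a number. Within the data shown here, what the measured compounds show is confined to the limit of > 32500 nM in this assay, at which 1 of the 2 values shown sits, so no step between measured compounds is available to size the change that follows.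

Compound 3 `COc1cc(-c2nn(-c3cccc(NC(=O)Nc4cccc(C(F)(F)F)c4)c3)cc2-c2ccncc2)ccc1Cl` differs from compound 1 in one place: hydrogen in place of trifluoromethyl on an aromatic carbon. Among the measured compounds shown here, with no measured pair showing this change, the expectation rests on compound 1 and on the change itself. In this assay compound 3 is expected to lose some potency against compound 1, a step of a 2.0-fold higher number from compound 1 to compound 3 (0.31 log units; beyond the scatter) that is estimated to be modest yet beyond the usual scatter, with a real chance that the reading ends at a limit. Compound 3 is accordingly estimated at 2600 nM in this assay, within a range from 900 nM to 9000 nM.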

Compound 3, concentration for total growth inhibition: 3210 nM
Compound 3: middle estimate off by 1.2-fold (0.09 log units), on the low side; measured number inside the range.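

In this assay, hydrogen in place of trifluoromethyl on the urea aryl ring gives a 2.5-fold higher number from compound 1 to compound 3 (0.40 log units; beyond the scatter), the first sized step available in this series. The second trifluoromethyl group therefore contributes to the reading but is not needed for a measurable one: compound 3 still gives a number, 3210 nM. No measurement shown gives a cause for this step, and the pair speaks only for this one carbon and this one change.

Still open, going by these compounds, is whether the step holds with a methyl group, a chlorine atom or an amine on that carbon, and what happens when the remaining trifluoromethyl group also gives way to hydrogen. Compound 2 gives > 32500 nM, which is a limit and not a number, and it differs from compound 1 and compound 3 in more than one place, so the part played by its urea aryl ring cannot be separated from that of its other changes.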